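The compounds below may be only part of what the source reports. "The series", "measured", "known", "first", "only" and "open" are said of these compounds alone.

Compound 1 `C[C@H](NC(=O)[C@@]1(Cc2ccccc2)CCN1C(=O)OCc1ccccc1)C(=O)NC(C)(C)C` and compound 2 `C[C@H](NC(=O)[C@@]1(Cc2ccccc2)CCN1C(=O)OCc1ccccc1)C(=O)NCc1ccccc1` share one core and differ only in the group on one amide-type nitrogen. In an ADME assay on HELF cells (Homo sapiens) for cytotoxicity, with a stated time of 3 days (a lower number here means that less compound is tolerated, a higher number that more compound is tolerated), compound 1 gives only a limit, > 100000 nM, and no number. In this assay compound 2 gives 42000 nM. That result for compound 2 is the only actual number shown. The other result, for compound 1, is a limit (the limit of > 100000 nM in this assay, at which 1 of the 2 values shown sits). The measured step is an at least 2.3-fold lower number from compound 1 to compound 2 (0.37 log units; beyond the scatter), so putting benzyl in place of tert-butyl on that nitrogen left compound 2 less tolerated.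

Compound 3 `C[C@H](NC(=O)[C@@]1(Cc2ccccc2)CCN1C(=O)OCc1ccccc1)C(=O)NC1CCCCC1` alters compound 2 at the same nitrogen: cyclohexyl in place of benzyl on an amide-type nitrogen. Among the compounds with values here, the only measured step that bears on this position is an at least 2.3-fold lower number from compound 1 to compound 2 (0.37 log units; beyond the scatter), in which an aromatic six-membered ring arriving on that nitrogen lowered the number beyond the scatter. Taking the aromatic ring away again while keeping a six-membered ring is expected to move the number part of the way back, by a modest amount at most, a 1.4-fold higher number from compound 2 to compound 3 (0.15 log units; within the scatter). Compound 3 is therefore estimated at 60000 nM, with a range from 25000 nM to 150000 nM.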

Compound 3, half-maximal cytotoxic concentration: 46000 nM
The estimate for compound 3 lay 1.3-fold (0.12 log units) above the measured number; the measured number falls inside the stated range.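

On the amide-type nitrogen, the aromatic benzyl ring and the non-aromatic cyclohexyl ring cannot be told apart in this assay, with a 1.1-fold higher number from compound 2 to compound 3 (0.04 log units; within the scatter). An aromatic ring is therefore not needed for a number lower than that of the tert-butyl compound, as the non-aromatic ring also gives an at least 2.1-fold lower number from compound 1 to compound 3 (0.33 log units; beyond the scatter). The size of that second step remains only a bound, because compound 1 gives a limit and not a number: the limit of > 100000 nM in this assay, at which 1 of the 3 values shown sits.

The compounds shown leave open how far the tert-butyl compound really lies from the two ring compounds, and whether its difference from them belongs to the open, branched shape of tert-butyl or to the presence of a ring in the others. They also do not tell how a straight hexyl chain, a small methyl group, or a cyclohexyl ring carrying an amine or a carboxylic acid on this nitrogen would read in this assay.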